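A few compounds are considered here, and "the series" means these few. Any claim that something is new, unique, unknown or untested is made for them only; others in the source may bear on it.

Measured compounds:
Compound 1 `Nc1ccccc1NC(=O)c1ccc(CSC(=S)N2CCN(Cc3ccccn3)CC2)cc1` gives 20.7% in a functional assay on A-375 cells (Homo sapiens) for antiproliferative activity, read by CCK-8 assay, with a stated time of 72 h, tested at 2 uM; on this read-out lower numbers stand for a weaker effect and higher numbers for a stronger effect at the one concentration tested.
Compound 2 `COc1ccc(N2CCN(C(=S)SCc3ccc(C(=O)Nc4ccccc4N)cc3)CC2)cc1` gives 28.1% in this assay.
Compound 3 `Nc1ccccc1NC(=O)c1ccc(CSC(=S)N2CCN(c3ncccn3)CC2)cc1` gives 24% in this assay.

All three share one core and differ only in the group on an amine nitrogen in a ring. Their numbers all lie within the scatter of one another: the steps of a number 3.3 percentage points higher from compound 1 to compound 3 (within the scatter) and a number 4.1 percentage points lower from compound 2 to compound 3 (within the scatter) are small, and so is a number 7.4 percentage points higher from compound 1 to compound 2 (within the scatter). Compound 4 `Nc1ccccc1NC(=O)c1ccc(CSC(=S)N2CCN(Cc3cccnc3)CC2)cc1` carries (pyridin-3-yl)methyl in place of pyrimidin-2-yl on an amine nitrogen in a ring. The exchanges already measured at this position bear directly on this change, and none of them moved the read-out beyond the scatter, so nothing in these data points to a real shift. Compound 4 is therefore expected to show a number 1 percentage points lower from compound 3 to compound 4 (within the scatter), a step inside the scatter. The estimate for compound 4 in this assay is 23%, with a range from 13% to 33%.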

Compound 4, a percentage reported as inhibition, at one concentration (the size of the read-out at that concentration, not a potency): 31.5%
Compound 4: the middle estimate sits 8.5 percentage points below what was measured; the range from low to high includes it.
By their numbers in this assay, from the lowest: compounds 1, 3, 2 and 4 (each within the scatter of the next, the first and the last beyond it).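

In this assay, among these compounds, pyridin-3-yl in place of pyridin-2-yl on a saturated chain carbon bound to an amine nitrogen in a ring gives a number 10.8 percentage points higher from compound 1 to compound 4 (beyond the scatter), the first exchange at this position to pass the scatter, though only modestly. The other exchanges give a number 7.5 percentage points higher from compound 3 to compound 4 (within the scatter) and a number 3.4 percentage points higher from compound 2 to compound 4 (within the scatter), so the new group stands apart only from the (pyridin-2-yl)methyl group. Nothing available gives a reason for this difference. Open, going by these compounds, is whether (pyridin-4-yl)methyl, or a longer chain carrying pyridin-3-yl, would go further. A read-out at one concentration also tells only of a stronger or weaker effect at that concentration.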